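This account rests on a few compounds, and the source may have more. Where it says the series, first, only, none or still open, it means among the compounds named here.

Series so far, in a functional assay on CCRF-CEM cells (Homo sapiens) for inhibition, read by MTT assay, with a stated time of 72 h; a lower number here means a stronger inhibitor, a higher number a weaker inhibitor:
- compound 1 `COc1cc(NC(C)CCCNC(=O)Nc2cccc(F)c2)c2ncccc2c1` gives 21000 nM
- compound 2 `COc1cc(NC(C)CCCNC(=O)NNC(=O)Nc2ccc(Cl)cc2)c2ncccc2c1` gives 108000 nM
- compound 3 `COc1cc(NC(C)CCCNC(=O)NNC(=O)Nc2ccc(C(F)(F)F)cc2)c2ncccc2c1` gives 18000 nM

Compound 3 and compound 1 stand within the scatter of each other, and compound 2 stands clear of both. Next in line is compound 4 `COc1cc(NC(C)CCCNC(=O)NNC(=O)Nc2cccc(F)c2)c2ncccc2c1`, not yet measured. The change is 3-fluorophenyl in place of 4-(trifluoromethyl)phenyl on an amide-type nitrogen.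

Among the compounds with values here, two measured steps bear on this. The closer guide is a 6.0-fold lower number from compound 2 to compound 3 (0.78 log units; beyond the scatter), which changes one group on an aromatic carbon with the rest held, and it shows that this end of the molecule can move the number by a modest amount. Less clean is a 5.1-fold higher number from compound 1 to compound 2 (0.71 log units; beyond the scatter), where ((4-chlorophenyl)carbamoyl)amino replaces 3-fluorophenyl on an amide-type nitrogen. Within the data shown here, no measured compound pairs 3-fluorophenyl with the linker of compound 3, so the size of this step rests on thin data.

With this linker, compound 3 reads 18000 nM and compound 2 reads 108000 nM, and compound 4 is expected to fall between them. The expected move is a 2.2-fold higher number from compound 3 to compound 4 (0.35 log units; beyond the scatter), a modest step towards a higher number. For compound 4 the estimate is 40000 nM, with an expected range of 13000 nM to 110000 nM.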

Compound 4, half-maximal inhibitory concentration: 98000 nM
Compound 4: the middle estimate sits 2.5-fold (0.39 log units) below what was measured; the measured number falls inside the stated range.
By their numbers in this assay, from the lowest: compounds 3 and 1 (each within the scatter of the next); then compounds 4 and 2 (each within the scatter of the next).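

In this assay, a 5.4-fold higher number from compound 3 to compound 4 (0.74 log units; beyond the scatter) shows that the number at this position depends on which aryl group sits on the amide-type nitrogen, while a 1.1-fold lower number from compound 2 to compound 4 (0.04 log units; within the scatter) leaves 3-fluorophenyl and 4-chlorophenyl indistinguishable, so among the three groups seen with this linker only 4-(trifluoromethyl)phenyl stands apart. The earlier step between compound 1 and compound 2 changed the linker and the aryl group together, whereas a 4.7-fold higher number from compound 1 to compound 4 (0.67 log units; beyond the scatter) holds 3-fluorophenyl constant and so isolates the change to ((3-fluorophenyl)carbamoyl)amino, which alone moves the number beyond the scatter. No measurement available here explains why 4-(trifluoromethyl)phenyl differs from the other two groups.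

The compounds shown leave open whether the difference of compound 3 belongs to trifluoromethyl itself or would also appear with another group on the phenyl ring, such as a nitrile, a methoxy group or an amine. They also leave open whether 4-(trifluoromethyl)phenyl would give a comparable number on the linker of compound 1, and so whether the cost of the longer linker seen with 3-fluorophenyl holds for other aryl groups.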